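The source may hold more compounds than are shown below. What is called first, only, known or untested is meant among the compounds shown, and "the series" means these compounds.

Compound 1 `O=C(CCCCCCN1C(=O)/C(=N\O)c2cc(Br)ccc21)NO`: 80 nM
Compound 2 `Cc1ccc2c(c1)/C(=N/O)C(=O)N2CCCCCCC(=O)NO`: 2440 nM
Compound 3 `CO/N=C1/C(=O)N(CCCCCCC(=O)NO)c2ccc(Br)cc21`: 1680 nM

All three were tested in a functional assay on ASPC1 cells (Homo sapiens) for antiproliferative activity, read by sulforhodamine B assay, with a stated time of 48 h; on this read-out lower numbers stand for stronger inhibition and higher numbers for weaker inhibition. Compound 1 and compound 2 differ in one place only: methyl in place of bromo on an aromatic carbon. That single change made a 31-fold higher number from compound 1 to compound 2 (1.48 log units; beyond the scatter), a large loss of activity. Compound 3 shares much with compound 1, but the difference between the two cores is not broken down here. Compound 4 `CO/N=C1/C(=O)N(CCCCCCC(=O)NO)c2ccc(C)cc21` has not been measured yet; it differs from compound 3 by methyl in place of bromo on an aromatic carbon, the same change as between compound 1 and compound 2, at the same place. For compound 4 this change is expected to make a 12-fold higher number from compound 3 to compound 4 (1.08 log units; beyond the scatter), a step of similar direction and roughly similar size, because the identical change gave a 31-fold higher number from compound 1 to compound 2 (1.48 log units; beyond the scatter). Compound 4 is therefore expected to give 20000 nM in this assay, with a likely range from 5000 nM to 80000 nM.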

Compound 4, half-maximal inhibitory concentration: 5480 nM
Estimate against measurement, compound 4: 3.6-fold (0.56 log units) above; the measured number falls inside the stated range.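

In this assay, methyl in place of bromo on the second core again weakens the result, with a 3.3-fold higher number from compound 3 to compound 4 (0.51 log units; beyond the scatter). The direction carries over from one core to the other, but the size does not: the same change on two cores in this assay, a 31-fold higher number (1.48 log units; beyond the scatter) from compound 1 to compound 2 and a 3.3-fold higher number (0.51 log units; beyond the scatter) from compound 3 to compound 4, 9.4-fold (0.97 log units) apart, beyond the scatter of two such steps. The loss seen on one core therefore cannot be taken as the size of the loss on another, and these two pairs show neither why the sizes differ nor whether the direction would hold on a further core.

The compounds shown leave open how chloro, fluoro or an amine would behave on this aromatic carbon. They also leave open whether a longer chain would change the size of the bromo-to-methyl step.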